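Adding a bromine to a weak lipoxygenase inhibitor

A few compounds are considered here, and "the series" means these few. Any claim that something is new, unique, unknown or untested is made for them only; others in the source may bear on it.

Two compounds share a core in which a small ring carrying two nitrogens and a carbonyl is joined to a six-membered aromatic ring with one nitrogen. Compound 1 is `O=C1NCCN(c2ccccn2)N1` and in a functional assay on cells for inhibition of Polyunsaturated fatty acid 5-lipoxygenase (Homo sapiens) (on this read-out higher numbers stand for weaker inhibition and lower numbers for stronger inhibition), compound 1 gives 8600 nM. Compound 2, `CC1CN(c2cccc(F)n2)NC(=O)N1`, carries a methyl and a fluoro in addition, and in this assay compound 2 gives 6000 nM. Compound 1 thus holds the higher of the two numbers, but the gap to compound 2 lies within the scatter of repeated measurements, so the two cannot be told apart.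

Compound 3 is `O=C1NCCN(c2cccc(Br)n2)N1`. It differs from compound 1 by one change: bromo in place of hydrogen on an aromatic carbon. Among the measured compounds shown here, no measured pair shows what this change does, and the one other compound offers no clear direction. The step from compound 1 to compound 3, a 1.3-fold lower number from compound 1 to compound 3 (0.12 log units; within the scatter), is therefore expected to be small, with no direction beyond the scatter. Compound 3 is estimated at 6500 nM, within a range from 2000 nM to 20000 nM.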

Compound 3, half-maximal inhibitory concentration: 4600 nM
For compound 3 the middle estimate is 1.4-fold (0.15 log units) above the measured one; the range from low to high includes it.
By their numbers in this assay, from the lowest: compounds 3, 2 and 1 (each within the scatter of the next).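

Among the compounds shown here, this is the first direct test of this position: compound 1 and compound 3 differ only by a bromo on an aromatic carbon next to the ring nitrogen, so any shift in this assay can be tied to that one change. The result is a 1.9-fold lower number from compound 1 to compound 3 (0.27 log units; within the scatter), which means this read-out shows no clear gain or loss from placing a bromine atom here. No measurement at hand explains the step or says what the bromine does in the cells.

On these data alone, it remains open whether a different group at the same place, such as an amine, a carboxylic acid or a longer chain, would move the number beyond the scatter. As far as these compounds go, it is also open whether any change at this position can turn these weak inhibitors into clearly stronger ones.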